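The source may report more compounds than this note shows. Statements on the series, on what has been measured and on what is new or still open speak of the compounds shown alone.

Two amides of the shared core have been run in an assay on LtK cells with ATP-sensitive inward rectifier potassium channel 11 (Homo sapiens) as the target; a lower number here means that less compound is needed, a higher number that more compound is needed for the effect. Compound 1 `CCC(CC)C(=O)Nc1c(C(O)(C(F)(F)F)C(F)(F)F)ccc2ccccc12` carries a pentan-3-yl group on the carbonyl carbon; in this assay compound 1 gives 4340 nM. Among the compounds with values here, compound 2 `CC(C)=CC(=O)Nc1c(C(O)(C(F)(F)F)C(F)(F)F)ccc2ccccc12` carries a 2-methylprop-1-en-1-yl group in the same place, and in this assay compound 2 gives 46 nM, the lowest of the two numbers so far; the only step into it, a 94-fold lower number from compound 1 to compound 2 (1.97 log units; beyond the scatter), is also the only measured step in the set. Compound 3 `O=C(Nc1c(C(O)(C(F)(F)F)C(F)(F)F)ccc2ccccc12)C1CCC1` is the next member: the change is cyclobutyl in place of 2-methylprop-1-en-1-yl on a carbonyl carbon, the two compounds having the same atoms joined differently, so the group on the carbonyl carbon now holds a four-membered ring of carbon only and no double bond outside aromatic rings. Within the data shown here, the one measured step bears on this only loosely: it shows that the group on the carbonyl carbon can move the number a long way, compound 1 standing far above compound 2. Cyclobutyl is neither measured group; the expected outcome is a rise from compound 2, a 6.5-fold higher number from compound 2 to compound 3 (0.81 log units; beyond the scatter), smaller than the gap back to compound 1. For compound 3 the estimate in this assay is 300 nM, with a range from 60 nM to 1500 nM.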

Compound 3, half-maximal effective concentration: 45 nM
Estimate against measurement, compound 3: 6.7-fold (0.82 log units) above, and the stated range ends above it.
By their numbers in this assay, from the lowest: compounds 3 and 2 (each within the scatter of the next); then compound 1.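

In this assay, cyclobutyl and 2-methylprop-1-en-1-yl on the carbonyl carbon cannot be told apart (a 1.0-fold lower number from compound 2 to compound 3 (0.01 log units; within the scatter)), so this exchange of a group without a ring for a four-membered ring of the same atom count leaves the number unchanged within the scatter. A double bond outside aromatic rings is therefore not needed in this group for a number at this level, and its absence does not separate the high number of compound 1 from the rest, since pentan-3-yl also lacks one yet the step to cyclobutyl remains large (a 96-fold lower number from compound 1 to compound 3 (1.98 log units; beyond the scatter)). No measurement is available that accounts for the gap between pentan-3-yl and the two four-carbon groups.

Still open, from the compounds shown here alone, is how far the low number extends across groups on the carbonyl carbon: cyclopropyl, cyclopentyl, isopropyl and tert-butyl would show whether ring size or branching at the attached carbon tracks with it. A group carrying heteroatoms, such as a tetrahydrofuran ring or an amine, also remains untested in these compounds as a replacement for the all-carbon groups shown here.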